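Solubility notes: aryl swap on the fused core

The source may report more compounds than this note shows. Statements on the series, on what has been measured and on what is new or still open speak of the compounds shown alone.

Measured compounds:
compound 1, `Cc1cc(C23CC(Nc4nc5n(n4)CCCC[C@H]5c4ccc(F)c(F)c4F)(C2)C3)ncn1`: 1 ug/mL
compound 2, `Cc1nnc(-c2ccc(Nc3nc4n(n3)CCCN4c3cccc(Cl)c3)cc2)o1`: < 0.1 ug/mL
compound 3, `Cc1nnc(C23CCC(Nc4nc5n(n4)CCCN5c4cccc(Cl)c4)(CC2)CC3)o1`: 132 ug/mL

In a physicochemical assay for solubility, read by HPLC, in phosphate buffer, at pH 6.5 (on this read-out lower numbers stand for lower solubility and higher numbers for higher solubility), compound 1 gives 1 ug/mL and compound 3 gives 132 ug/mL. For compound 2 the read-out is only a limit, < 0.1 ug/mL. Compound 2 thus sits at the limit of < 0.1 ug/mL in this assay, at which 1 of the 3 values shown sits, at the low end of the three values shown.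

Compound 4, `Cc1nnc(-c2ccc(Nc3nc4n(n3)CCCN4c3ccc(OC(F)(F)F)cc3)cc2)o1`, is not yet measured. It differs from compound 2 in one place: 4-(trifluoromethoxy)phenyl in place of 3-chlorophenyl on a nitrogen on an aromatic ring in a ring. Among the measured compounds shown here, no pair of measured compounds shows this change, so its size cannot be read from a measured step. Compound 3 carries a different ring system in place of the phenyl of compound 2 and is not a guide here. With compound 2 reporting only a limit, no movement beyond the scatter is expected, and compound 4 is expected to stay near that limit. The estimate for compound 4 is 0.15 ug/mL, between 0.05 ug/mL and 0.6 ug/mL. The expected step of an at least 1.5-fold higher number from compound 2 to compound 4 (0.17 log units; that floor lies within the scatter) is small, with a fair chance that compound 4 again returns only a limit.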

Compound 4, solubility: < 0.1 ug/mL
Compound 4 ended at the assay's limit (the forecaster's own chance of this, stated with the estimate: 55%); middle value at least 1.5-fold (0.17 log units) from the limit.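

In this assay, compound 2 and compound 4 both return only a limit, so no step can be read for 4-(trifluoromethoxy)phenyl in place of 3-chlorophenyl; both sit at the same limit: the limit of < 0.1 ug/mL in this assay, at which 2 of the 4 values shown sit.

The compounds shown leave open how compound 2 and compound 4 compare beneath that limit.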